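This account rests on a few compounds, and the source may have more. Where it says the series, first, only, none or still open, it means among the compounds named here.

Compound 1 `O=C(c1ccc(F)cc1)c1ccn(-c2ccc3c(c2)B(O)OC3)c1` and compound 2 `COc1cc(C(=O)c2ccn(-c3ccc4c(c3)B(O)OC4)c2)cc(OC)c1OC` share one core and differ only in the groups on the ring attached to the carbonyl. In an ADME assay on L929 cells (Mus musculus) for cytotoxicity, read by resazurin assay, with a stated time of 72 h (on this read-out lower numbers stand for stronger inhibition and higher numbers for weaker inhibition), compound 2 gives 1.15 ug/mL. In this assay compound 1 gives > 10 ug/mL, which is a limit of the assay rather than a number, as the limit of > 10 ug/mL in this assay, at which 1 of the 2 values shown sits, notes. Compound 3 `NCc1ccc(C(=O)c2ccn(-c3ccc4c(c3)B(O)OC4)c2)cc1` changes compound 1 at one place: aminomethyl in place of fluoro on an aromatic carbon. Going by the values given here, with no measured step from compound 1, the change is expected to stay within the usual scatter, a number no higher from compound 1 to compound 3 (the limit leaves the size open). Compound 3 is therefore estimated at 10 ug/mL in this assay, between 3 ug/mL and 30 ug/mL.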

Compound 3, half-maximal inhibitory concentration: > 10 ug/mL
Compound 3: only a limit was reported; the forecaster's own chance of this, stated with the estimate: 50%; the middle value sits exactly at the limit.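

No step can be read from compound 1 to compound 3, because both compounds stop at a limit rather than a number: the limit of > 10 ug/mL in this assay, at which 2 of the 3 values shown sit. On these data alone, whether aminomethyl in place of fluoro changes the result in this assay, and by how much, stays open.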